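This account rests on a few compounds, and the source may have more. Where it says the series, first, only, none or still open, it means among the compounds named here.

Compound 1 `O=C(Nc1ccccc1O)C1CCc2ccccc2N1`: 2230 nM
Compound 2 `O=C(Nc1cc(C(F)(F)F)cc(C(F)(F)F)c1)C1CCc2ccccc2N1`: 8410 nM
Compound 3 `O=C(Nc1cc(C(F)(F)F)cc(C(F)(F)F)c1)C1CCc2ccccc2N1C(=O)c1cccc(Cl)c1`: 420 nM

Of the compounds shown here, three have been tested in a functional assay on NCI-H23 cells (Homo sapiens) for cytotoxicity, read by sulforhodamine B assay, with a stated time of 72 h; a lower number here means a stronger inhibitor of growth, a higher number a weaker inhibitor of growth. Compound 1 gives 2230 nM, compound 2 gives 8410 nM, and compound 3 gives 420 nM. The difference between the cores of compound 1 and compound 2 is not broken down here; their values alone show compound 1 with the lower number of the two. Compound 3 differs from compound 2 in one place: (3-chlorophenyl)carbonyl in place of hydrogen on a nitrogen on an aromatic ring in a ring. That step produced a 20-fold lower number from compound 2 to compound 3 (1.30 log units; beyond the scatter). Compound 4 `O=C(Nc1ccccc1O)C1CCc2ccccc2N1C(=O)c1cccc(Cl)c1` has not yet been measured; it stands to compound 1 exactly as compound 3 stands to compound 2: (3-chlorophenyl)carbonyl in place of hydrogen on a nitrogen on an aromatic ring in a ring. Because the same change once gave a 20-fold lower number from compound 2 to compound 3 (1.30 log units; beyond the scatter), compound 4 is expected to show a lower number than compound 1, with an estimated step of an 8.9-fold lower number from compound 1 to compound 4 (0.95 log units; beyond the scatter), though this rests on a single prior example. Compound 4 is thus estimated at 250 nM, likely between 50 nM and 1200 nM.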

Compound 4, concentration for 50% growth inhibition: 11600 nM
Compound 4: middle estimate off by 46-fold (1.67 log units), on the low side; the measured number lies above the stated range.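

In this assay, (3-chlorophenyl)carbonyl in place of hydrogen on a nitrogen on an aromatic ring in a ring gave a 5.2-fold higher number from compound 1 to compound 4 (0.72 log units; beyond the scatter), so the change did not carry over between these two cores in direction or size: the same change on two cores in this assay, a 20-fold lower number (1.30 log units; beyond the scatter) from compound 2 to compound 3 and a 5.2-fold higher number (0.72 log units; beyond the scatter) from compound 1 to compound 4, 100-fold (2.02 log units) apart, beyond the scatter of two such steps This shows that, in these two pairs, the outcome of the change depends on the core it is placed on. It does not show which part of the cores is responsible, and two pairs give no rule for any other core.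

The compounds shown leave open whether a core bearing a methoxy group or a single trifluoromethyl group would follow compound 3 or compound 4. They also leave open whether a plain acetyl group on that nitrogen would split the two cores in the same way.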